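Taking a Ring Hydroxy Away from Compound 3

The compounds below may be only part of what the source reports. "The series", "measured", "known", "first", "only" and "open" are said of these compounds alone.

In a functional assay on MCF7 cells (Homo sapiens) for cytotoxicity, read by colorimetric assay and neutral red uptake, with a stated time of 72 h (a lower number here means a stronger inhibitor, a higher number a weaker inhibitor), compound 1 (`CO[C@@H](C(=O)N[C@H]1CCCCNC1=O)[C@H](O)[C@@H](O)[C@H](O)/C=C/C(C)(C)C`) gives 1300 nM as the starting point. Compound 2 (`CO[C@@H](C(=O)N[C@H]1CCCCNC1=O)[C@@H]1OC(C)(C)O[C@H](/C=C/C(C)(C)C)[C@@H]1O`) gives > 150000 nM as a limit of the assay, not a number. Compound 3 (`CO[C@@H](C(=O)N[C@H]1CC[C@@H](O)CNC1=O)[C@H](O)[C@@H](O)[C@H](O)/C=C/C(C)(C)C`) gives 23400 nM as the higher of the two true numbers, and its nearest neighbour is compound 1.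

Compound 4 (`CO[C@@H](C(=O)N[C@@H]1CCCCNC1=O)[C@H](O)[C@@H](O)[C@H](O)/C=C/C(C)(C)C`) has 2-oxoazepan-3-yl in place of 6-hydroxy-2-oxoazepan-3-yl on an amide-type nitrogen. Going by the values given here, one measured step bears on this change. Putting hydroxy in place of hydrogen on a saturated ring carbon gave an 18-fold higher number from compound 1 to compound 3 (1.26 log units; beyond the scatter) as a large rise beyond the scatter. Removing the hydroxy should therefore lower the number in this assay, but a single step is thin support, so a smaller drop than that rise is expected. The expected move is a 3.9-fold lower number from compound 3 to compound 4 (0.59 log units; beyond the scatter) on this reasoning. The estimate for compound 4 is 6000 nM with 1000 nM to 40000 nM as its expected range.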

Compound 4, half-maximal inhibitory concentration: 200 nM
The estimate for compound 4 lay 30-fold (1.48 log units) above the measured number; measured number below the stated range.
By their numbers in this assay, from the lowest: compound 4; then compound 1; then compound 3. At a limit, above all of these: compound 2.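

Replacing 6-hydroxy-2-oxoazepan-3-yl with 2-oxoazepan-3-yl gave a 120-fold lower number from compound 3 to compound 4 (2.07 log units; beyond the scatter) in this assay, yet this step carries two changes at once: the loss of the hydroxy and a switched stereocentre at a saturated ring carbon. Configuration alone accounts for part of the drop, with a 6.5-fold lower number from compound 1 to compound 4 (0.81 log units; beyond the scatter), and this part can be assigned to configuration because nothing else changes: the fact that compounds 1 and 4 differ only in the configuration as drawn The earlier compounds could not show this, as all of them are drawn alike at this stereocentre.

On these data alone, whether a ring hydroxy would raise the number as much in the configuration of compound 4 remains open. So does the effect of an amine or a fluorine on that ring in either configuration.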